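The compounds below may be only part of what the source reports. "The series", "measured", "known", "first", "only" and "open" are said of these compounds alone.

Measured in an ADME assay on MRC5 cells (Homo sapiens) for cytotoxicity, read by neutral red uptake; on this read-out higher numbers stand for lower toxicity in this test and lower numbers for higher toxicity in this test:

Compound 1 `CSc1nc(-c2cccc(Br)c2)c(C#N)c(=O)[nH]1`: > 64000 nM
Compound 2 `O=c1[nH]c(SCc2ccc(-c3ccccc3)cc2)nc2ccccc12`: > 64000 nM
Compound 3 `COc1ccccc1CSc1nc2ccccc2c(=O)[nH]1`: "not determined" (no result reported)

In this assay compound 2 gives > 64000 nM, which is a limit of the assay and not a number. Compound 1 gives > 64000 nM, and this too is a limit. The two entries therefore cannot be ranked against each other, and compound 3 has no result to compare. What the set offers is a single shared mark: the limit of > 64000 nM in this assay, at which 2 of the 3 values shown sit.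

Compound 4 `O=c1[nH]c(SCc2ccc([N+](=O)[O-])cc2)nc2ccccc12` has not yet been measured. It carries nitro in place of phenyl on an aromatic carbon, para to a large group (nitro in place of phenyl on an aromatic carbon). For the measured compounds named here, no two measured compounds differ in one place only, and none of them carries a nitro group, so no measured step can serve as a guide. The expectation in this assay is therefore no step beyond the usual scatter, though the uncertainty runs mainly toward lower numbers, which would mean higher toxicity in this test. The expected change is an at least 1.2-fold lower number from compound 2 to compound 4 (0.10 log units; that floor lies within the scatter). For compound 4 the estimated value is 50000 nM, with an expected range from 16000 nM to 64000 nM.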

Compound 4, half-maximal cytotoxic concentration: > 64000 nM
Compound 4: no number, only a limit (the forecaster's own chance of this, stated with the estimate: 55%); middle value at least 1.2-fold (0.10 log units) from the limit.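

In this assay, compound 2 and compound 4 each give only a limit of the assay and not a number, so no step can be read between them. The compounds shown leave open whether nitro in place of phenyl on an aromatic carbon changes the read-out at all.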